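Hydroxy in Place of Hydrogen: Expected Cytotoxicity of Compound 3

The source may report more compounds than this note shows. Statements on the series, on what has been measured and on what is new or still open speak of the compounds shown alone.

Compound 1 `COc1cc(CCc2ccccc2O)cc(OC)c1` reaches only a limit in an ADME assay on BC cells (Homo sapiens) for cytotoxicity, read by colorimetric assay; on this read-out lower numbers stand for stronger inhibition and higher numbers for weaker inhibition: compound 1 gives > 77500 nM, which is a limit of the assay rather than a number. Compound 2 `COc1cc(CCc2ccccc2O)cc(O)c1C` likewise shows only a limit, giving > 77500 nM in this assay. Both values sit at the limit of > 77500 nM in this assay, at which 2 of the 2 values shown sit. Compound 3 `COc1cc(CCc2ccccc2O)c(O)c(OC)c1` differs from compound 1 by hydroxy in place of hydrogen on an aromatic carbon. Going by the values given here, no step between measured compounds is available, so the change is expected to leave the read-out at the limit, and the step that the limit leaves unreadable from compound 1 to compound 3 is estimated as nothing beyond the scatter. Compound 3 is therefore expected to give about 100000 nM, with a range from 40000 nM to 300000 nM.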

Compound 3, half-maximal inhibitory concentration: > 72900 nM
Compound 3 gave a limit, no number; the forecaster's own chance of this, stated with the estimate: 85%; the middle value lies beyond the limit too.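

Going by these compounds alone, compound 1 and compound 3 both give only limits in this assay, not numbers, so no step between them can be read. The compounds shown leave open whether hydroxy in place of hydrogen changes the read-out at all.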